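The compounds below may be only part of what the source reports. "The series", "measured", "known", "first", "only" and "open" are said of these compounds alone.

Measured compounds:
compound 1, `CNc1nc(OC)nc2c1ncn2C1O[C@H](CO)[C@H](O[C@@H]2OC(CO)[C@H](OP(=O)(O)O)C(OP(=O)(O)O)[C@@H]2O)[C@@H]1OP(=O)(O)O`, gives 34% in a functional assay on the whole organism with Rattus norvegicus as the target; a higher number here means a larger maximal response, a lower number a smaller maximal response
compound 2, `Nc1ncnc2c1ncn2C1O[C@H](CO)[C@H](O[C@@H]2OC(CO)[C@H](OP(=O)(O)O)C(OP(=O)(O)O)[C@@H]2O)[C@@H]1OP(=O)(O)O`, gives 35% in this assay
compound 3, `CNc1ncnc2c1ncn2C1O[C@H](CO)[C@H](O[C@@H]2OC(CO)[C@H](OP(=O)(O)O)C(OP(=O)(O)O)[C@@H]2O)[C@@H]1OP(=O)(O)O`, gives 37% in this assay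

Compound 3 holds the highest of the three numbers in this assay, but its steps to compound 2 and to compound 1 are both within the scatter, so the three compounds cannot be told apart on these data. The step of a number 3 percentage points higher from compound 1 to compound 3 (within the scatter) came with hydrogen in place of methoxy on an aromatic carbon; the step of a number 2 percentage points higher from compound 2 to compound 3 (within the scatter) came with methyl in place of hydrogen on a nitrogen on an aromatic ring.

Compound 4, `O=P(O)(O)OC1[C@@H](OP(=O)(O)O)C(CO)O[C@@H](O[C@@H]2[C@H](OP(=O)(O)O)C(n3cnc4c(NC5CCCCC5)ncnc43)O[C@@H]2CO)[C@H]1O`, differs from compound 3 by cyclohexyl in place of methyl on a nitrogen on an aromatic ring. Going by the values given here, only the step from compound 2 to compound 3 touches the same nitrogen, and that step stayed within the scatter; no measured step puts cyclohexyl in that place, so the series gives no direct precedent. The expectation for compound 4 is therefore a step of a number 1 percentage points higher from compound 3 to compound 4 (within the scatter) in this assay, not beyond the scatter, with a wide range to cover the untested change. Compound 4 is estimated at 38%, between 22% and 56%.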

Compound 4, largest response reached (reported as maximal response), in percent of the reference or control that the assay uses: 45%
Compound 4: middle estimate off by 7 percentage points, on the low side, and the stated range covers the measured number.
By their numbers in this assay, from the lowest: compounds 1, 2, 3 and 4 (each within the scatter of the next, the first and the last beyond it).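

The nitrogen on an aromatic ring now carries hydrogen, methyl or cyclohexyl across the series, and in this assay the largest of these groups gives a number 8 percentage points higher from compound 3 to compound 4 (within the scatter) and, measured against hydrogen, a number 10 percentage points higher from compound 2 to compound 4 (within the scatter) in the same read-out. Neither step leaves the scatter, so going from one carbon to a six-membered non-aromatic ring of carbon at this place gives no maximal response that can be told apart from those of the smaller groups. Nothing available bears on why the response holds up with this change.

On these data alone, whether an open hexyl chain, a benzyl group or a chain ending in an amine on this nitrogen would stay within the scatter remains open. Also open, as far as these compounds go, is whether methoxy on the aromatic carbon, as in compound 1, would behave the same way alongside cyclohexyl.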